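The source may hold more compounds than are shown below. What is called first, only, known or untested is meant among the compounds shown, and "the series" means these compounds.

Measured in a functional assay on KB cells (Homo sapiens) for antiproliferative activity, read by MTT assay, with a stated time of 72 h (a lower number here means a stronger inhibitor, a higher number a weaker inhibitor), so far:
Compound 1 `COc1ccc(-c2cc(C(=O)O)sc2-c2cc(OC)c(OC)c(OC)c2)cc1O` gives 21800 nM
Compound 2 `COc1ccc(-c2ccsc2-c2cc(OC)c(OC)c(OC)c2)cc1[N+](=O)[O-]` gives 21000 nM

Compound 2 stands level with compound 1, the two values lying within the scatter of each other. The change hydroxy in place of nitro on an aromatic carbon puts hydroxy in place of nitro on an aromatic carbon, ortho to a methoxy group, and leads from compound 2 to compound 3 `COc1ccc(-c2ccsc2-c2cc(OC)c(OC)c(OC)c2)cc1O` as the next entry. Within the data shown here, no measured step covers this change, so the expectation is a judgement with wide uncertainty: a large move towards a lower number in this assay is expected. The estimated move is a 70-fold lower number from compound 2 to compound 3 (1.85 log units; beyond the scatter) on this reading. For compound 3 the estimated value is 300 nM with an expected range from 10 nM to 8000 nM in this assay.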

Compound 3, half-maximal inhibitory concentration: 1530 nM
Beside the measured number, compound 3's estimate is 5.1-fold (0.71 log units) below it; low and high end bracket the measured number.
By their numbers in this assay, from the lowest: compound 3; then compounds 2 and 1 (each within the scatter of the next).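

In this assay hydroxy in place of nitro on an aromatic carbon, ortho to a methoxy group, gives a 14-fold lower number from compound 2 to compound 3 (1.14 log units; beyond the scatter) and shows that this position is sensitive to the group it carries. Hydrogen in place of carboxy on an aromatic carbon gives a 14-fold lower number from compound 1 to compound 3 (1.15 log units; beyond the scatter) and, as compound 1 carries the same hydroxy, that hydroxy does not bring the lower number while the carboxy stands on the core. No supporting data bear on the reason for either step.

As far as these compounds go, whether an amine or a fluorine at the hydroxy position would hold the lower number stays open. So does the effect of a methyl ester or a primary amide in place of the carboxy.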